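This account rests on a few compounds, and the source may have more. Where it says the series, first, only, none or still open, it means among the compounds named here.

Measured compounds:
Compound 1 `CNC(=O)c1cc(C(=O)NCCCC2CNCCO2)cn(Cc2ccccc2)c1=O`: in a physicochemical assay for solubility (on this read-out higher numbers stand for higher solubility and lower numbers for lower solubility), compound 1 gives >= 194 ug/mL, which is a limit of the assay and not a number.
Compound 2 `CNC(=O)c1cc(C(=O)NC2CC2)cn([C@H](C)c2ccccc2)c1=O`: in this assay compound 2 gives >= 168 ug/mL, likewise a limit and not a number.

Compound 1 thus stands only at a limit, namely (the limit of >= 194 ug/mL in this assay, at which 1 of the 2 values shown sits), and compound 2 sits at the limit of >= 168 ug/mL in this assay, at which 1 of the 2 values shown sits. Going by the values given here, since neither value is a measured number, no step between the two is known, and no pair differing in a single place has been measured. Compound 3 `CNC(=O)c1cc(C(=O)NCC(C)C)cn(Cc2ccccc2)c1=O` has not yet been measured in this assay. It differs from compound 1 in one place: isopropyl in place of 2-(morpholin-2-yl)ethyl on a saturated chain carbon bound to an amide-type nitrogen. Among the compounds with values here, with no measured step to lean on, the size of the change can only be guessed, but a fall beyond the usual scatter from compound 1 to compound 3 is expected in this assay, estimated as an at least 3.8-fold lower number from compound 1 to compound 3 (0.58 log units; beyond the scatter). Compound 3 is accordingly expected to give about 50 ug/mL, within a range of 12 ug/mL to 190 ug/mL.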

Compound 3, solubility: 43 ug/mL
The estimate for compound 3 lay 1.2-fold (0.07 log units) above the measured number; the range from low to high includes it.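

In this assay, isopropyl in place of 2-(morpholin-2-yl)ethyl on a saturated chain carbon bound to an amide-type nitrogen gives an at least 4.5-fold lower number from compound 1 to compound 3 (0.65 log units; beyond the scatter), the only step among the compounds shown that can be read. This step is a lower bound on the true size, since compound 1 stands at a limit and not at a number: the limit of >= 194 ug/mL in this assay, at which 1 of the 3 values shown sits. The result shows that a change at this place alone can move the read-out beyond the scatter, which the two limits by themselves could not show.

The step exchanges the ring, the chain and the hetero atoms together, which leaves open which of them carries the difference and how large the full step is. A simple alkyl chain ending in a primary amine or a carboxylic acid at this place would help to separate these parts.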